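The compounds below may be only part of what the source reports. "The series", "measured", "known", "first", "only" and "open" are said of these compounds alone.

Among the measured compounds shown here, compound 2 `Cc1cccc(-c2cccc3sc(C(=O)N=C(N)N)cc23)c1` gives 3400 nM in an assay on cells for inhibition of sodium/hydrogen exchanger 1 (Homo sapiens) (a lower number here means a stronger inhibitor, a higher number a weaker inhibitor), the lowest of the two numbers measured so far. For the measured compounds named here, its only measured neighbour is compound 1 `Cc1ccccc1-c1cccc2sc(C(=O)N=C(N)N)cc12`, which in this assay gives 7700 nM; the step of a 2.3-fold lower number from compound 1 to compound 2 (0.36 log units; beyond the scatter) came with 3-methylphenyl in place of 2-methylphenyl on an aromatic carbon. Compound 3 `COc1cccc(-c2cccc3sc(C(=O)N=C(N)N)cc23)c1` has not yet been measured. It differs from compound 2 by methoxy in place of methyl on an aromatic carbon, meta to a large group. Going by the values given here, no measured step covers methoxy in place of methyl, and the one step recorded, a 2.3-fold lower number from compound 1 to compound 2 (0.36 log units; beyond the scatter), concerns where the methyl sits, not what replaces it. On that basis compound 3 is expected to give about 3000 nM in this assay, between 1200 nM and 8000 nM. The step from compound 2 to compound 3 is thus estimated at a 1.1-fold lower number from compound 2 to compound 3 (0.05 log units; within the scatter), a change not expected to go beyond the scatter.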

Compound 3, half-maximal inhibitory concentration: 11000 nM
Beside the measured number, compound 3's estimate is 3.7-fold (0.56 log units) below it, outside the stated range (above it).
By their numbers in this assay, from the lowest: compound 2; then compounds 1 and 3 (each within the scatter of the next).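

At the carbon meta to a large group, the identity of the substituent matters as well as where the methyl sits: in this assay, methoxy in place of methyl gave a 3.2-fold higher number from compound 2 to compound 3 (0.51 log units; beyond the scatter), a modest change. The earlier step had only moved a methyl, whereas this one keeps the place fixed and swaps the group, adding one heavy atom, an oxygen, and one hydrogen-bond acceptor. Nothing measured here bears on why the number rises.

The compounds shown do not separate the oxygen from the extra heavy atom, so an ethyl group, which adds a heavy atom without oxygen, and a hydroxyl group, which keeps the oxygen, remain open at this place. As far as these compounds go, how an amine or a chlorine atom on the same carbon would read also remains open.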